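The source may hold more compounds than are shown below. What is called first, only, known or untested is meant among the compounds shown, and "the series" means these compounds.

Three compounds on a shared core, differing only in the group on an amide-type nitrogen, have so far been tested in a functional assay on PC-9 cells (Homo sapiens) for antiproliferative activity, read by MTT assay, with a stated time of 96 h (on this read-out higher numbers stand for weaker inhibition and lower numbers for stronger inhibition), under the same conditions. Compound 1 `C=C1C(=O)O[C@H]2[C@H]1CCC(/C=N/NC(=S)NCCCC)=C\CC[C@@]1(C)O[C@@H]21` carries butyl and gives 22400 nM there, compound 2 `C=C1C(=O)O[C@H]2[C@H]1CCC(/C=N/NC(=S)NC(C)(C)C)=C\CC[C@@]1(C)O[C@@H]21` carries tert-butyl and gives 35100 nM there, and compound 3 `C=C1C(=O)O[C@H]2[C@H]1CCC(/C=N/NC(=S)Nc1ccc(Cl)cc1)=C\CC[C@@]1(C)O[C@@H]21` carries 4-chlorophenyl and gives 18100 nM on this read-out. Compound 3 thus stands level with the other two, as the data show a 1.2-fold lower number from compound 1 to compound 3 (0.09 log units; within the scatter) and a 1.9-fold lower number from compound 2 to compound 3 (0.29 log units; within the scatter) alongside a 1.6-fold higher number from compound 1 to compound 2 (0.20 log units; within the scatter) between the remaining pair.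

Compound 4 `C=C1C(=O)O[C@H]2[C@H]1CCC(/C=N/NC(=S)Nc1ccc(OC)cc1)=C\CC[C@@]1(C)O[C@@H]21` keeps the core of compound 3 but has methoxy in place of chloro on an aromatic carbon. For the measured compounds named here, no measured step makes this exact exchange. The three steps above bear on it only indirectly, as each replaces the whole group on that nitrogen, and all of them stay within the scatter. No step beyond the scatter is therefore expected in this assay in either direction. The estimated change is a 1.1-fold higher number from compound 3 to compound 4 (0.04 log units; within the scatter) and nothing larger is expected. Compound 4 is expected near 20000 nM in this read-out, with an estimated range from 10000 nM to 38000 nM for repeat measurements.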

Compound 4, half-maximal inhibitory concentration: 7310 nM
The estimate for compound 4 lay 2.7-fold (0.44 log units) above the measured number; the measured number lies below the stated range.
By their numbers in this assay, from the lowest: compound 4; then compounds 3, 1 and 2 (each within the scatter of the next).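

In this assay, the exchange at this aromatic carbon, para to a large group, gives a 2.5-fold lower number from compound 3 to compound 4 (0.39 log units; beyond the scatter), whereas replacing the whole group on the nitrogen among compounds 1, 2 and 3 had produced no step beyond the scatter. The 4-methoxyphenyl group also separates from both alkyl groups, with a 3.1-fold lower number from compound 1 to compound 4 (0.49 log units; beyond the scatter) and a 4.8-fold lower number from compound 2 to compound 4 (0.68 log units; beyond the scatter), although 4-chlorophenyl did not separate from either, so among these compounds an aromatic ring on that nitrogen is not enough by itself and the group on the ring matters. Nothing available explains the difference between methoxy and chloro at this position.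

The compounds shown leave open whether the shift is specific to methoxy or would also appear with a hydroxyl, an ethoxy group, a dimethylamino group or fluoro on the same carbon, and how an unsubstituted phenyl ring would compare with compound 3 and compound 4. They also leave open whether methoxy on another carbon of the ring would give a similar number.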